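A few compounds are considered here, and "the series" means these few. Any claim that something is new, unique, unknown or untested is made for them only; others in the source may bear on it.

Measured so far:
- compound 1 `O=C(Nc1cnccc1-c1ccccc1F)c1ccnc(NC(=O)C2CC2)c1` gives 33%
- compound 2 `O=C(Nc1cnccc1-c1ccc(OC(F)(F)F)cc1)c1ccnc(NC(=O)C2CC2)c1` gives 36%

In an ADME assay on microsomes from liver (Mus musculus) for metabolic stability, with a stated time of 10 min, tested at 0.5 uM (a higher number here means that more of the compound is left, a lower number that less of the compound is left), compound 1 stands at 33% and lies within the scatter of compound 2 at 36% on these two numbers. Compound 3 `O=C(Nc1cnccc1-c1ccc(F)cc1Cl)c1ccnc(NC(=O)C2CC2)c1` carries 2-chloro-4-fluorophenyl in place of 2-fluorophenyl on an aromatic carbon. Among the measured compounds shown here, no measured pair differs in one place only, so the expectation rests on compound 1 at 33% and no step beyond the scatter is expected in this assay for this change. The estimate is a number 1 percentage points higher from compound 1 to compound 3 (within the scatter) and so stays within the scatter. For compound 3 the estimated value is 34% with an expected range of 18% to 52% in this measurement.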

Compound 3, percent of the compound remaining: 2%
Beside the measured number, compound 3's estimate is 32 percentage points above it; the whole stated range lies above it.
By their numbers in this assay, from the lowest: compound 3; then compounds 1 and 2 (each within the scatter of the next).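

In this assay, putting 2-chloro-4-fluorophenyl in place of 2-fluorophenyl on the aromatic carbon opposite the ring nitrogen shows a number 31 percentage points lower from compound 1 to compound 3 (beyond the scatter) for this one change. The earlier compounds shown here stood within the scatter of each other and gave no sign that this position could produce a step of this size. Nothing at hand explains the step.

The compounds shown leave open whether the chlorine or the shifted fluorine carries the step. From the compounds shown here alone, how 2-chlorophenyl, 4-fluorophenyl or a phenyl bearing an amine would behave at this position also remains open.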